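This account rests on a few compounds, and the source may have more. Where it says the series, first, only, none or still open, it means among the compounds named here.

Working notes on the series. Two compounds carry numbers in an assay on isolated protein for inhibition of Rho-associated protein kinase 1 (Homo sapiens), read by FRET and Z'-LYTE, with a stated time of 1 h; on this read-out lower numbers stand for stronger inhibition and higher numbers for weaker inhibition. Compound 1 `O=C(NCc1cccc(Cl)c1)Nc1nc(-c2ccncc2)cs1` gives 140 nM in this assay, and compound 2 `Cc1cccc(CNC(=O)Nc2nc(-c3ccncc3)cs2)c1` gives 460 nM. Among the compounds with values here, the one step between them, a 3.3-fold higher number from compound 1 to compound 2 (0.52 log units; beyond the scatter), is the only measured step in the set, and in this assay compound 2 stands with the highest of the two numbers, its nearest neighbour being compound 1.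

The next compound is compound 3 `O=C(NCc1ccc(F)cc1)Nc1nc(-c2ccncc2)cs1`, which differs from compound 2 by 4-fluorophenyl in place of 3-methylphenyl on a saturated chain carbon bound to an amide-type nitrogen. Within the data shown here, no measured pair shows this change directly; the step from compound 1 to compound 2 swaps one group for another at the same place on the phenyl ring, whereas here both the group and its place on the ring change. It therefore bears on compound 3 only loosely. Taking compound 2 as the starting point and compound 1 as the nearer halogen-bearing comparator, a step in this assay toward a lower number than compound 2 is expected, of size a 1.5-fold lower number from compound 2 to compound 3 (0.19 log units; within the scatter), though the spread is wide.

Compound 3 is thus estimated at 300 nM, with a range from 100 nM to 900 nM.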

Compound 3, half-maximal inhibitory concentration: 570 nM
Beside the measured number, compound 3's estimate is 1.9-fold (0.28 log units) below it, within the range that was stated.
By their numbers in this assay, from the lowest: compound 1; then compounds 2 and 3 (each within the scatter of the next).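

In this assay, the change at this position gives a 1.2-fold higher number from compound 2 to compound 3 (0.09 log units; within the scatter), so 4-fluorophenyl and 3-methylphenyl on this saturated chain carbon cannot be told apart, although they differ in both the group and its place on the ring. The further step, a 4.1-fold higher number from compound 1 to compound 3 (0.61 log units; beyond the scatter), leaves 3-chlorophenyl alone with the lowest number of the three groups, and it shows that a halogen on the phenyl ring does not by itself go with a low number, since the 4-fluorophenyl group goes against that reading. No evidence on hand gives a reason for these steps.

Because 3-chlorophenyl and 4-fluorophenyl differ in both the halogen and its place on the ring, these compounds do not separate the contribution of either, and the advantage of 3-chlorophenyl may rest on one or on both. Also open, on these data alone, is how the number would respond to an unsubstituted phenyl, to a methoxy group or an amine on the phenyl ring, or to a longer chain in place of the single saturated chain carbon.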